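The source may hold more compounds than are shown below. What is called first, only, known or untested is meant among the compounds shown, and "the series" means these compounds.

In a functional assay on MCF7 cells (Homo sapiens) for inhibition, read by CCK-8 assay, with a stated time of 48 h (on this read-out higher numbers stand for weaker inhibition of growth and lower numbers for stronger inhibition of growth), compound 1 `Cc1ccc(CNc2nc(Nc3ccc(N4CCN(C)CC4)cn3)ncc2Cl)cc1` gives 38100 nM and compound 2 `CN1CCN(c2ccc(Nc3ncc(Cl)c(NCc4ccc(F)cc4)n3)nc2)CC1` gives 19300 nM. Between these two lies a 2.0-fold lower number from compound 1 to compound 2 (0.30 log units; within the scatter), so the two stand level.

Compound 3 `COc1ccccc1CNc1nc(Nc2ccc(N3CCN(C)CC3)cn2)ncc1Cl` returns only a limit of the assay, > 100000 nM, and not a number. On the numbers shown, compound 3 therefore stands at the limit of > 100000 nM in this assay, at which 1 of the 3 values shown sits. Two measured steps reach it: an at least 2.6-fold higher number from compound 1 to compound 3 (0.41 log units; beyond the scatter), and an at least 5.1-fold higher number from compound 2 to compound 3 (0.71 log units; beyond the scatter). Both are open-ended, so the true gaps may be wider.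

Compound 4 `CCc1ccc(Nc2nc(Nc3ccc(N4CCN(C)CC4)cn3)ncc2Cl)cc1` is the next to be read. Its difference from compound 3 is 4-ethylphenyl in place of 2-methoxybenzyl on a nitrogen on an aromatic ring, with 4-ethylphenyl in place of 2-methoxybenzyl on a nitrogen on an aromatic ring. Among the compounds with values here, no measured step covers this exact exchange. The nearest evidence is the pair of steps into compound 3, read in reverse, since compound 1 at 38100 nM and compound 2 at 19300 nM both lack the 2-methoxyphenyl group. A move away from that group is thus expected to give a lower number in this assay, of at least modest size, though with wide uncertainty.

The expected change is an at least 6.6-fold lower number from compound 3 to compound 4 (0.82 log units; beyond the scatter). For compound 4 the estimate is 15000 nM, with an expected range from 3000 nM to 70000 nM.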

Compound 4, concentration for 50% growth inhibition: 8230 nM
For compound 4 the middle estimate is 1.8-fold (0.26 log units) above the measured one; low and high end bracket the measured number.
By their numbers in this assay, from the lowest: compound 4; then compounds 2 and 1 (each within the scatter of the next). At a limit, above all of these: compound 3.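

Until now, this assay had shown only benzyl groups on this nitrogen, and the changes among them gave no step beyond the scatter except towards 2-methoxybenzyl. Compound 4 shows that this position also accepts 4-ethylphenyl, with a step beyond the scatter from each of the two benzyl compounds that give numbers: a 2.3-fold lower number from compound 2 to compound 4 (0.37 log units; beyond the scatter), and a 4.6-fold lower number from compound 1 to compound 4 (0.67 log units; beyond the scatter). The step from the 2-methoxybenzyl compound is the largest, an at least 12-fold lower number from compound 3 to compound 4 (1.08 log units; beyond the scatter), but it is open-ended, as compound 3 gives a limit of the assay and not a number: the limit of > 100000 nM in this assay, at which 1 of the 4 values shown sits.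

The compounds shown leave open whether the lower number goes with the aryl group standing directly on the nitrogen or with the ethyl group itself, since 4-methylphenyl and 4-fluorophenyl on this nitrogen do not appear among them. Also open, going by these compounds, is how a longer chain between the nitrogen and the ring, or a carboxylic acid or an amine on the 4-ethylphenyl ring, would read here.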